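This account rests on a few compounds, and the source may have more. Where it says the series, first, only, none or still open, it means among the compounds named here.

Measured compounds in a functional assay on HEK293 cells for agonist activity at D(4) dopamine receptor (Homo sapiens), read by FLIPR; on this read-out higher numbers stand for an effect only at larger amounts of compound and lower numbers for an effect already at smaller amounts:
- compound 1 `COc1ccccc1C1CCN(CC(=O)Nc2cccc(C)c2)CC1`: 420 nM
- compound 2 `Cc1cccc(NC(=O)CN2CCC(c3ccccc3)CC2)c1`: 170 nM
- compound 3 `Cc1cccc(NC(=O)CN2CCC(c3ccccc3C#N)CC2)c1`: 8 nM

Compound 3 gives the lowest number of the three. The nearest of the others is compound 2, and the step of a 21-fold lower number from compound 2 to compound 3 (1.33 log units; beyond the scatter) sets compound 3 well clear of it; compound 1 lies further off still, a 53-fold lower number from compound 1 to compound 3 (1.72 log units; beyond the scatter). All measured steps change only the group on an aromatic carbon: a 2.5-fold lower number from compound 1 to compound 2 (0.39 log units; beyond the scatter) is modest, while the two steps that bring in the nitrile are large, so the nitrile carries the gain seen in this assay.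

Compound 4 `Cc1cccc(NC(=O)CN2CCC(c3cccc(C#N)n3)CC2)c1` differs from compound 3 in one place: 6-cyanopyridin-2-yl in place of 2-cyanophenyl on a saturated ring carbon. The nitrile stays; the ring that bears it goes from an aromatic ring of carbon only to one with a hetero atom. Among the measured compounds shown here, no measured step touches this ring itself, so none gives a direct measure of the swap. For the measured compounds named here, the steps that bear on it are those showing the nitrile to be what matters, and the nitrile is retained. The expected step of a 1.9-fold higher number from compound 3 to compound 4 (0.27 log units; within the scatter) is therefore small, possibly within the scatter, with a slight lean toward a higher number in this assay. Compound 4 is estimated at 15 nM, with a range from 4 nM to 60 nM.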

Compound 4, half-maximal effective concentration: 36 nM
For compound 4 the middle estimate is 2.4-fold (0.38 log units) below the measured one, and the stated range covers the measured number.
By their numbers in this assay, from the lowest: compound 3; then compound 4; then compound 2; then compound 1.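

In this assay the nitrile alone does not settle the result: with it retained, a 4.5-fold higher number from compound 3 to compound 4 (0.65 log units; beyond the scatter) is a modest loss, so the ring that bears it also counts at this position. The 6-cyanopyridin-2-yl group still keeps part of the gain, with a 4.7-fold lower number from compound 2 to compound 4 (0.67 log units; beyond the scatter) and a 12-fold lower number from compound 1 to compound 4 (1.07 log units; beyond the scatter), which places it ahead of both phenyl and 2-methoxyphenyl on this saturated ring carbon. Nothing at hand explains the loss on going to the ring with a hetero atom.

The swap changes the ring atom and the place of the nitrile on the ring together, and the compounds shown do not separate the two; a 3-cyanophenyl group would bear directly on this. Also open, from the compounds shown here alone, is whether a carboxylic acid or an aminomethyl group could stand in for the nitrile on either ring.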